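The source may report more compounds than this note shows. Statements on the series, on what has been measured and on what is new or still open speak of the compounds shown alone.

Measured compounds:
compound 1 `CCc1ccc(OCC(=O)N(CC)Cc2cccs2)cc1` gives 67 nM in an assay on HEK293 cells for agonist activity at transient receptor potential cation channel subfamily M member 8 (Homo sapiens), read by fluorescence and calcium flux, with a stated time of 15 min; a lower number here means that less compound is needed, a higher number that more compound is needed for the effect
compound 2 `COc1ccc2oc(C(=O)N(Cc3cccs3)c3ccn[nH]3)cc2c1` gives 1.1 nM in this assay
compound 3 `Cc1ccc(OCC(=O)N(Cc2cccs2)c2ccccc2)cc1` gives 23 nM in this assay

Of these three numbers compound 1 has the highest, so it needs the most compound for the effect; compound 3 is nearest, with a lower number beyond the scatter, and compound 2 lies furthest away, with a much lower number. Compound 4 `CCN(Cc1cccs1)C(=O)COc1ccc(OC)cc1` has not yet been measured. It differs from compound 1 in one place: methoxy in place of ethyl on an aromatic carbon. Within the data shown here, no pair of measured compounds shows this exchange on its own, so its effect is not known from the data; compound 3, which carries a methyl instead of an ethyl but also a different group on the amide nitrogen, gives a lower number than compound 1, but that comparison mixes two changes. A modest step toward a lower number in this assay is expected, close to the scatter. Compound 4 is estimated at 40 nM, with a range of 12 nM to 150 nM, which is expected to be a step of a 1.7-fold lower number from compound 1 to compound 4 (0.22 log units; within the scatter).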

Compound 4, half-maximal effective concentration: 120 nM
Compound 4: the middle estimate sits 3.0-fold (0.48 log units) below what was measured; the measured number falls inside the stated range.
By their numbers in this assay, from the lowest: compound 2; then compound 3; then compounds 1 and 4 (each within the scatter of the next).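

In this assay, methoxy in place of ethyl on an aromatic carbon, para to a large group, gives a 1.8-fold higher number from compound 1 to compound 4 (0.25 log units; within the scatter). Among these compounds, this is the first view of this exchange on its own, and it shows that, on the core of compound 1, swapping one of these two groups for the other leaves the number within the scatter. No measurement shown bears on the reason for this result. As far as these compounds go, whether an amine, a carboxylic acid or a longer chain at this position would move the number stays open. So does whether the exchange would give the same result with the different amide group of compound 3.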